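The source may hold more compounds than are shown below. What is called first, only, known or untested is meant among the compounds shown, and "the series" means these compounds.

Measured in a functional assay for inhibition, with Homo sapiens as the target; on this read-out lower numbers stand for tighter binding and higher numbers for weaker binding:
- compound 1 `N#Cc1ccccc1C1OCC(C/C=C\CCC(=O)O)C(c2cccnc2)O1`: 245 nM
- compound 2 `O=C(O)CC/C=C\CC1COC(c2ccc([N+](=O)[O-])cc2)OC1c1cccnc1`: 933 nM
- compound 3 `Cc1ccc(OC(C)(C)C2OCC(C/C=C\CCC(=O)O)C(c3cccnc3)O2)cc1`: 631 nM

In this assay, compound 3 at 631 nM lies within the scatter of compound 2, and its number is higher than that of compound 1, beyond the scatter.

Compound 4 `CC(C)(Oc1ccc(F)cc1[N+](=O)[O-])C1OCC(C/C=C\CCC(=O)O)C(c2cccnc2)O1` has not yet been measured. It differs from compound 3 in one place: 4-fluoro-2-nitrophenyl in place of 4-methylphenyl on an oxygen on a saturated carbon. In words, this is 4-fluoro-2-nitrophenyl in place of 4-methylphenyl on an oxygen on a saturated carbon.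

Among the measured compounds shown here, only one measured step exchanges one such group for another: a 3.8-fold higher number from compound 1 to compound 2 (0.58 log units; beyond the scatter), with 4-nitrophenyl in place of 2-cyanophenyl on a saturated ring carbon. That step is modest but beyond the scatter. It sits at a different place from the present change, so it bears only loosely. The incoming group shares its nitro with compound 2 and a 2-substituted name with compound 1, so the direction is only a weak lean, resting on this single pair.

A modest step is expected, of about the size seen there: a 2.1-fold lower number from compound 3 to compound 4 (0.32 log units; beyond the scatter).

The estimate for compound 4 is 300 nM, with an expected range of 100 nM to 900 nM.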

Compound 4, dissociation constant: 2.51 nM
The estimate for compound 4 lay 120-fold (2.08 log units) above the measured number; the measured number lies below the stated range.
By their numbers in this assay, from the lowest: compound 4; then compound 1; then compounds 3 and 2 (each within the scatter of the next).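

In this assay, among the compounds shown here, the exchange of 4-methylphenyl for 4-fluoro-2-nitrophenyl on an oxygen on a saturated carbon gives a 250-fold lower number from compound 3 to compound 4 (2.40 log units; beyond the scatter) and so shows that the read-out is highly sensitive to the group at this place, which the earlier compounds could not show with only one group there. For the compounds shown here, this step is far larger than a 3.8-fold higher number from compound 1 to compound 2 (0.58 log units; beyond the scatter) at the saturated ring carbon, so the only earlier exchange of one such group for another gave no measure of how much could change here. The entering group has 10 heavy atoms against 7 and 2 hydrogen-bond acceptors against 0, but nothing measured here explains the size of the step.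

The compounds shown leave open which part of the exchange carries the step, as the nitro and the fluorine enter and the methyl leaves all at once, and a plain 2-nitrophenyl or 4-fluorophenyl on the same oxygen would begin to separate these. Also open, going by these compounds, is whether the step survives when an amine or a carboxylic acid stands in place of the nitro.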